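The source may hold more compounds than are shown below. What is called first, only, known or untested is meant among the compounds shown, and "the series" means these compounds.

Working notes on the series in a physicochemical assay for solubility, in phosphate buffer, with a stated time of 24 h, at pH 7.4, tested at 100 uM; on this read-out higher numbers stand for higher solubility and lower numbers for lower solubility. Compound 1 (`O=C(NCc1ccc(S(=O)(=O)c2cccc(C(F)(F)F)c2)cc1)N1Cc2ccncc2C1`), with 3-(trifluoromethyl)phenyl on the sulfonyl sulfur, gives 10000 nM. Compound 2 (`CCC(=O)N1CCC(S(=O)(=O)c2ccc(CNC(=O)N3Cc4ccncc4C3)cc2)CC1`) gives 216000 nM, and compound 3 (`O=C(NCc1ccc(S(=O)(=O)C2CCN(C3COC3)CC2)cc1)N1Cc2ccncc2C1`) gives 121000 nM. Two measured compounds therefore sit well clear of the third, and the position of compound 3 is fixed by two steps: a 1.8-fold lower number from compound 2 to compound 3 (0.25 log units; within the scatter), and a 12-fold higher number from compound 1 to compound 3 (1.08 log units; beyond the scatter).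

The next change leads to compound 4 (`O=C(NCc1ccc(S(=O)(=O)N2CCOCC2)cc1)N1Cc2ccncc2C1`), again on a sulfonyl sulfur: morpholin-4-yl in place of 1-(oxetan-3-yl)piperidin-4-yl on a sulfonyl sulfur. The large steps in this assay are a 22-fold higher number from compound 1 to compound 2 (1.33 log units; beyond the scatter), and a 12-fold higher number from compound 1 to compound 3 (1.08 log units; beyond the scatter). Both remove 3-(trifluoromethyl)phenyl, a group that neither compound 3 nor compound 4 carries, so they bear on this change only indirectly. The closer guide is a 1.8-fold lower number from compound 2 to compound 3 (0.25 log units; within the scatter), where the change stays within the non-aromatic part. For the measured compounds named here, no measured compound carries morpholin-4-yl, so the data do not test this group directly. No step beyond the scatter is expected in this assay. The expected step is a 1.2-fold lower number from compound 3 to compound 4 (0.08 log units; within the scatter). For compound 4 the estimated value is 100000 nM, with an expected range from 40000 nM to 220000 nM.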

Compound 4, solubility: 59000 nM
For compound 4 the middle estimate is 1.7-fold (0.23 log units) above the measured one, and the stated range covers the measured number.
By their numbers in this assay, from the lowest: compound 1; then compound 4; then compounds 3 and 2 (each within the scatter of the next).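

In this assay, for the compounds shown here, morpholin-4-yl is the only group among the four joined to the sulfonyl sulfur through a ring nitrogen, and it shows that non-aromatic groups at this place are not interchangeable: the change from 1-(oxetan-3-yl)piperidin-4-yl gives a 2.1-fold lower number from compound 3 to compound 4 (0.31 log units; beyond the scatter) and the change from 1-propanoylpiperidin-4-yl gives a 3.7-fold lower number from compound 2 to compound 4 (0.56 log units; beyond the scatter) in the same direction, whereas the earlier step between those two piperidine compounds stayed within the scatter. Replacing 3-(trifluoromethyl)phenyl with morpholin-4-yl still gives a 5.9-fold higher number from compound 1 to compound 4 (0.77 log units; beyond the scatter) so a higher number than that of compound 1 is not confined to the two groups with a piperidin-4-yl ring. No measurement among the data explains why morpholin-4-yl stands apart from the other two non-aromatic groups.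

The compounds shown leave open whether the lower number goes with the smaller group, the ring oxygen or the link through ring nitrogen, since these change together. A piperidin-1-yl or 4-methylpiperazin-1-yl group on the sulfonyl sulfur, or a carboxylic acid on the piperidine ring, would be needed to separate these features.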